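Trimming the urea chain from compound 1 to compound 4

The source may report more compounds than this note shows. Statements on the series, on what has been measured and on what is new or still open speak of the compounds shown alone.

Compound 1: `CCCCNC(=O)N1CC1C#N` — 14000 nM
Compound 2: `N#CC1CN1C(=O)Nc1cccc2ccccc12` — 2400 nM
Compound 3: `N#CC1CN1C(=O)Nc1ccc(C(F)(F)F)cc1` — 1300 nM

All three were measured in a functional assay on WiDr cells (Homo sapiens) for inhibition; a lower number here means a stronger inhibitor, a higher number a weaker inhibitor. Compound 1 gives the highest number of the three; compound 2 and compound 3 both give lower numbers, each beyond the scatter, so compound 1 is the weakest inhibitor of this set. Compound 4 `CNC(=O)N1CC1C#N` differs from compound 1 in one place: hydrogen in place of propyl on a saturated chain carbon bound to an amide-type nitrogen. Within the data shown here, no measured pair shows this step, so its size is unknown. Because compound 1 already stands at 14000 nM, and the chain is cut back to methyl, a further loss seems more likely than a gain. The expected step is a 2.1-fold higher number from compound 1 to compound 4 (0.33 log units; beyond the scatter). Compound 4 is therefore estimated at 30000 nM, within 10000 nM to 100000 nM.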

Compound 4, half-maximal inhibitory concentration: 21000 nM
For compound 4 the middle estimate is 1.4-fold (0.15 log units) above the measured one; low and high end bracket the measured number.
By their numbers in this assay, from the lowest: compounds 3 and 2 (each within the scatter of the next); then compounds 1 and 4 (each within the scatter of the next).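

Among these compounds, the step of a 1.5-fold higher number from compound 1 to compound 4 (0.18 log units; within the scatter) shows for the first time that, in this assay, this position accepts hydrogen in place of propyl with no difference beyond the scatter. Butyl and methyl therefore cannot be told apart here, and chain length over this range does not separate compound 1 from compound 4. No measurement available offers an explanation for this result. Open, on these data alone, is whether a longer chain, such as octyl, would give a number beyond the scatter. Also open, as far as these compounds go, is whether an amine or a carboxylic acid at the chain end would do so.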